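This account rests on a few compounds, and the source may have more. Where it says the series, first, only, none or still open, it means among the compounds named here.

The measured compounds in a functional assay on DU-145 cells (Homo sapiens) for cytotoxicity, read by MTT assay; a lower number here means a stronger inhibitor, a higher number a weaker inhibitor:

- Compound 1 `COCCO[C@H](CC=C(C)C)C1=CC(=O)c2c(O)ccc(O)c2C1=O` gives 43200 nM
- Compound 2 `CC(C)=CC[C@@H](OCC(C)O)C1=CC(=O)c2c(O)ccc(O)c2C1=O` gives 16100 nM
- Compound 3 `CC(C)=CC[C@@H](OC(=O)CC(O)c1ccccc1)C1=CC(=O)c2c(O)ccc(O)c2C1=O` gives 17000 nM

Compound 3 stands second highest of these three numbers. Its number and that of compound 2 are within the usual scatter of each other, so no order between them can be claimed; compound 1 gives the higher number of the set. Among the compounds with values here, the one step measured between neighbours is a 2.7-fold lower number from compound 1 to compound 2 (0.43 log units; beyond the scatter), a modest change at the ether side chain. Compound 4 `CC(C)=CC[C@@H](OC(=O)C1CCCCO1)C1=CC(=O)c2c(O)ccc(O)c2C1=O` differs from compound 3 by oxan-2-yl in place of 2-hydroxy-2-phenylethyl on a carbonyl carbon. Within the data shown here, no measured step touches the ester carbonyl, so the change from compound 3 to compound 4 has no direct precedent here; the single measured step shows only that small changes on this scaffold have moved the number modestly. Compound 4 is therefore expected to stay close to compound 3, with a step of a 1.1-fold higher number from compound 3 to compound 4 (0.02 log units; within the scatter) expected to lie within the scatter. Compound 4 is estimated at 18000 nM, with a range from 6000 nM to 50000 nM.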

Compound 4, half-maximal inhibitory concentration: 24700 nM
The estimate for compound 4 lay 1.4-fold (0.14 log units) below the measured number, and the stated range covers the measured number.
By their numbers in this assay, from the lowest: compounds 2, 3, 4 and 1 (each within the scatter of the next, the first and the last beyond it).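

In this assay the swap on the carbonyl carbon gives only a small shift (a 1.5-fold higher number from compound 3 to compound 4 (0.16 log units; within the scatter)), so on this ester the number holds within the scatter when oxan-2-yl, with its non-aromatic ring and no hydrogen-bond donor, replaces 2-hydroxy-2-phenylethyl, with its aromatic ring and one donor. Changing the whole group on the oxygen also stays within the scatter, both against the 2-hydroxypropyl ether (a 1.5-fold higher number from compound 2 to compound 4 (0.19 log units; within the scatter)) and against the 2-methoxyethyl ether (a 1.7-fold lower number from compound 1 to compound 4 (0.24 log units; within the scatter)), even though those two ethers lie beyond the scatter of each other (a 2.7-fold lower number from compound 1 to compound 2 (0.43 log units; beyond the scatter)). No independent measurement is available that bears on this result.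

The compounds shown leave open whether an amine or a carboxylic acid on this carbonyl carbon would move the number beyond the scatter. On these data alone, a longer chain in that place is equally open.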